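The compounds below may be only part of what the source reports. "The series", "measured", "known", "first", "only" and "open" are said of these compounds alone.

Notes on the series, which shares one core across compound 1 `Cc1noc(-c2nc(C)c3c(c2N)C(=O)N(Cc2cccc(F)c2)C3=O)n1`, compound 2 `Cc1noc(-c2nc(C)c3c(c2N)C(=O)N(Cc2ccccc2F)C3=O)n1` and compound 3 `Cc1noc(-c2nc(C)c3c(c2N)C(=O)N(Cc2ccncc2)C3=O)n1`. In a physicochemical assay for solubility, using the shake flask method, in simulated intestinal fluid, measured as kinetic solubility, with a stated time of 2 h, at 25 degrees C, at pH 6.5 (a lower number here means a less soluble compound, a higher number a more soluble compound), compound 1 gives < 5000 nM, which is a limit of the assay and not a number. Compound 2 gives < 5000 nM, which is also a limit, so its standing is known only as that limit.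

Compound 3 differs from compound 2 on a saturated chain carbon bound to an amide-type nitrogen in a ring, where 2-fluorobenzyl gives way to (pyridin-4-yl)methyl: pyridin-4-yl in place of 2-fluorophenyl on a saturated chain carbon bound to an amide-type nitrogen in a ring.

Among the compounds with values here, the one measured step bearing on this change is a step that the two limits leave unreadable from compound 1 to compound 2, which exchanges 3-fluorophenyl for 2-fluorophenyl at the same place. Within the data shown here, it offers no size to carry forward, and no measured step covers a pyridin-4-yl group. Compound 3 is expected to lie close to the limit because of the limit of < 5000 nM in this assay, at which 2 of the 2 values shown sit. The estimated a number no lower from compound 2 to compound 3 (the limit leaves the size open) therefore has no direction that the data can support, and another limit in this assay is quite possible. In this assay, the expected value for compound 3 is 5000 nM, with an estimated range of 1500 nM to 20000 nM.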

Compound 3, solubility: 26400 nM
Estimate against measurement, compound 3: 5.3-fold (0.72 log units) below, and the stated range ends below it.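

In this assay, within the data shown here, the exchange of 2-fluorophenyl for pyridin-4-yl on a saturated chain carbon bound to an amide-type nitrogen in a ring gives an at least 5.2-fold higher number from compound 2 to compound 3 (0.72 log units; beyond the scatter), the first readable step at this place. The exchange of 3-fluorophenyl for pyridin-4-yl at the same place gives an at least 5.2-fold higher number from compound 1 to compound 3 (0.72 log units; beyond the scatter), so the shift appears from both fluorophenyl compounds and does not rest on a single starting point. The step between compound 1 and compound 2 cannot be read, and both of these steps give only a lower bound on their size, since their starting values are a limit and not a number: the limit of < 5000 nM in this assay, at which 2 of the 3 values shown sit.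

The compounds shown leave open how large the step really is and whether it is specific to pyridin-4-yl, as a pyridin-3-yl group, an unsubstituted phenyl or a morpholine on the same chain carbon would be needed to separate the ring nitrogen from the loss of the fluorine. They also leave open whether the step holds with any other group in place of the methyl groups on the shared core.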